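Fluorine moves around the ring of a chalcone imidazole

The source may report more compounds than this note shows. Statements on the series, on what has been measured and on what is new or still open speak of the compounds shown alone.

Compound 1, `O=C(/C=C/c1cccc(F)c1)c1ccc(-n2ccnc2)cc1`: in an assay on isolated protein for inhibition of Amine oxidase [flavin-containing] B (Homo sapiens) (a higher number here means a weaker inhibitor, a lower number a stronger inhibitor), compound 1 gives > 10000 nM, which is a limit of the assay and not a number.
Compound 2, `O=C(/C=C/c1ccc(Br)cc1)c1ccc(-n2ccnc2)cc1`: in this assay compound 2 gives 320 nM.
Compound 3, `Cc1ccc(/C=C/C(=O)c2ccc(-n3ccnc3)cc2)cc1`: in this assay compound 3 gives 320 nM.

Compound 3 stands level with compound 2, the step of no change at the digits printed from compound 2 to compound 3 (within the scatter) lying within the scatter. Against compound 1 it stands far off: an at least 31-fold lower number from compound 1 to compound 3 (1.49 log units; beyond the scatter), as does an at least 31-fold lower number from compound 1 to compound 2 (1.49 log units; beyond the scatter); both steps rest on a value that is only a limit (the limit of > 10000 nM in this assay, at which 1 of the 3 values shown sits), so their true size is unknown.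

Compound 4, `O=C(/C=C/c1ccccc1F)c1ccc(-n2ccnc2)cc1`, differs from compound 3 in one place: 2-fluorophenyl in place of 4-methylphenyl on a double-bonded chain carbon bound to a double-bonded chain carbon. Among the measured compounds shown here, the step that bears on this change is an at least 31-fold lower number from compound 1 to compound 3 (1.49 log units; beyond the scatter), which replaced a fluorophenyl with the 4-methylphenyl and was large; compound 4 runs that exchange backwards, though with the fluorine now at the 2-position, a placement no measured compound carries. On that basis the expected step is a 9.4-fold higher number from compound 3 to compound 4 (0.97 log units; beyond the scatter), a rise in the number smaller than the unbounded step seen from compound 1. Compound 4 is estimated at 3000 nM, with a range from 500 nM to 20000 nM.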

Compound 4, half-maximal inhibitory concentration: > 10000 nM
Compound 4 was reported as a limit; the forecaster's own chance of this, stated with the estimate: 35%; middle value at least 3.3-fold (0.52 log units) away from the limit.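

In this assay, putting 2-fluorophenyl in place of 4-methylphenyl on the double-bonded chain carbon gives an at least 31-fold higher number from compound 3 to compound 4 (1.49 log units; beyond the scatter), and putting it in place of 4-bromophenyl gives an at least 31-fold higher number from compound 2 to compound 4 (1.49 log units; beyond the scatter); both steps are large and beyond the scatter. With this result, a fluorine at the 2-position joins a fluorine at the 3-position in falling out of the measurable range, whereas both compounds with a group at the 4-position, compound 2 and compound 3, give readable values. The values of compound 1 and compound 4 are each a limit, so the true size of these steps is unknown, and the step between those two compounds cannot be read: the limit of > 10000 nM in this assay, at which 2 of the 4 values shown sit.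

From the compounds shown here alone, what remains open is whether the loss follows the fluorine itself or the placement of any group away from the 4-position, since every fluorine shown sits at the 2- or 3-position and every other group at the 4-position. A 4-fluorophenyl group would test the first reading, and a 2-methylphenyl or 3-bromophenyl group the second.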